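Lengthening the Alkoxy Chain by One Carbon

The source may hold more compounds than are shown below. What is called first, only, known or untested is meant among the compounds shown, and "the series" means these compounds.

Among the compounds with values here, compound 2 `CCCCCCOc1ccc(Cl)cc1COc1ccccc1C(=O)Nc1cccnc1` gives 520 nM in an assay on lysate for inhibition of phosphatidylcholine:ceramide cholinephosphotransferase 2 (Homo sapiens), read by HPLC, with stated times of 30 min and 2 h (a lower number here means a stronger inhibitor, a higher number a weaker inhibitor), the lowest of the two numbers measured so far, while compound 1 `COCCOc1ccc(Cl)cc1COc1ccccc1C(=O)Nc1cccnc1` gives 11600 nM. Within the data shown here, the single measured step, a 22-fold lower number from compound 1 to compound 2 (1.35 log units; beyond the scatter), is the only guide available. Compound 3 `CCCCCCCOc1ccc(Cl)cc1COc1ccccc1C(=O)Nc1cccnc1` differs from compound 2 by methyl in place of hydrogen on a saturated chain carbon, six bonds along the chain from an oxygen on an aromatic ring. That earlier step replaced a short chain carrying a second oxygen with a plain longer one; here only one carbon is added to an already long chain. For compound 3 a step of a 1.3-fold lower number from compound 2 to compound 3 (0.11 log units; within the scatter) is therefore expected, small and within the scatter. Compound 3 is estimated at 400 nM, with a range of 150 nM to 1200 nM.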

Compound 3, half-maximal inhibitory concentration: 430 nM
Estimate against measurement, compound 3: 1.1-fold (0.03 log units) below; the range from low to high includes it.
By their numbers in this assay, from the lowest: compounds 3 and 2 (each within the scatter of the next); then compound 1.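

In this assay methyl in place of hydrogen, six bonds along the chain from an oxygen on an aromatic ring, gives a 1.2-fold lower number from compound 2 to compound 3 (0.08 log units; within the scatter) and so the two compounds cannot be told apart at this chain length. Pentyl in place of methoxy gives a 27-fold lower number from compound 1 to compound 3 (1.43 log units; beyond the scatter) and so the large step seen earlier remains with this chain. No measurement shown here speaks to the reason for either step. Still open, on these data alone, is whether a longer chain, or an amine or a carboxylic acid on this chain, would keep the number at this level.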